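The source may report more compounds than this note shows. Statements on the series, on what has been measured and on what is new or still open speak of the compounds shown alone.

Compound 1 `O=S(=O)(Nc1ccc2oc(-c3ccccc3)nc2c1)c1cccs1` was tested in an ADME assay on HEK293 cells (Homo sapiens) for cytotoxicity, read by resazurin assay, with a stated time of 48 h (on this read-out higher numbers stand for lower toxicity in this test and lower numbers for higher toxicity in this test), where compound 1 gives 97000 nM. That is the only plain number shown for this read-out. Compound 2 `O=S(=O)(Nc1ccc(-c2nc3ccccc3o2)cc1)c1ccc(O)cc1` gives > 100000 nM in this assay, which is a limit of the assay and not a number. Going by the values given here, the other value shown is therefore (the limit of > 100000 nM in this assay, at which 1 of the 2 values shown sits), so compound 1 stands as the one compound with a measured figure. Compound 3 `O=S(=O)(Nc1ccc2oc(-c3ccccc3)nc2c1)c1ccc(Cl)cc1` has not been measured yet. It differs from compound 1 in a single place: 4-chlorophenyl in place of thiophen-2-yl on a sulfonyl sulfur. Among the compounds with values here, no measured pair of compounds shows this change, so there is no step to lean on. The expected step of a 1.2-fold lower number from compound 1 to compound 3 (0.08 log units; within the scatter) in this assay is none beyond the usual scatter of repeated measurements. Compound 3 is thus expected to give about 80000 nM, within a range from 30000 nM to 100000 nM, with a real chance that only a limit is reported.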

Compound 3, half-maximal cytotoxic concentration: 65000 nM
Estimate against measurement, compound 3: 1.2-fold (0.09 log units) above; low and high end bracket the measured number.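

Going by these compounds alone, the first measured step at this position, on a sulfonyl sulfur, is a 1.5-fold lower number from compound 1 to compound 3 (0.17 log units; within the scatter) in this assay. A five-membered aromatic ring with a hetero atom, thiophen-2-yl, and a six-membered aromatic ring of carbon only, 4-chlorophenyl, therefore cannot be told apart in this test. Within this pair, the change of ring type and the added chlorine leave the cell read-out within the variation expected from repeating the measurement.

As far as these compounds go, whether a non-aromatic group on the sulfonyl sulfur, such as a short alkyl chain or a chain ending in an amine or a carboxylic acid, would move the number beyond that scatter stays open. Compound 2 gives a limit of the assay and not a number, so it adds no measured step here: the limit of > 100000 nM in this assay, at which 1 of the 3 values shown sits.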